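Removing both chlorines from the anilide and cytotoxicity

The source may hold more compounds than are shown below. What is called first, only, known or untested is meant among the compounds shown, and "the series" means these compounds.

Compound 1, `CC(CSc1nnc(-c2ccncc2)s1)C(=O)NCc1ccccc1Cl`: in an ADME assay on BHK-21 cells (Mesocricetus auratus) for cytotoxicity, with a stated time of 3 days (a lower number here means that less compound is tolerated, a higher number that more compound is tolerated), compound 1 gives > 50000 nM, which is a limit of the assay and not a number.
Compound 2, `CC(CSc1nnc(-c2ccncc2)s1)C(=O)Nc1ccc(Cl)cc1`: in this assay compound 2 gives > 50000 nM, again a limit.
Compound 3, `CC(CSc1nnc(-c2ccncc2)s1)C(=O)Nc1ccc(Cl)cc1Cl`: in this assay compound 3 gives > 50000 nM, also a limit.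

Within the data shown here, compound 3 therefore stands where every measured compound stands, at the limit of > 50000 nM in this assay, at which 3 of the 3 values shown sit; no compound in this set has yet given a real number. The change to compound 4, `CC(CSc1nnc(-c2ccncc2)s1)C(=O)Nc1ccccc1`, is phenyl in place of 2,4-dichlorophenyl on an amide-type nitrogen. Among the measured compounds shown here, three measured steps touch the same nitrogen: a step that the two limits leave unreadable from compound 1 to compound 2, a step that the two limits leave unreadable from compound 1 to compound 3 and a step that the two limits leave unreadable from compound 2 to compound 3. The last of these is the nearest in kind, since it adds a single chloro to the ring, whereas compound 4 takes two away. All three steps run between limits, so none of them gives a readable size or direction, and none suggests that changing this ring moves the read-out at all. The expectation for compound 4 is accordingly a step that the limit leaves unreadable from compound 3 to compound 4, that is, nothing beyond the scatter. The estimate for compound 4 in this assay is 80000 nM, with a range from 30000 nM to 300000 nM, and most probably the assay will again report only a limit.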

Compound 4, half-maximal cytotoxic concentration: > 50000 nM
Compound 4: only a limit was reported; the forecaster's own chance of this, stated with the estimate: 85%; the middle value does not contradict the limit.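

Compound 4 gives > 50000 nM in this assay, which is again a limit and not a number. The steps from compound 1, compound 2 and compound 3 to compound 4 therefore cannot be read. Whether changing the group on the amide-type nitrogen moves the half-maximal cytotoxic concentration at all stays open, with every compound shown in the same place: the limit of > 50000 nM in this assay, at which 4 of the 4 values shown sit.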